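The source may report more compounds than this note shows. Statements on the series, on what has been measured and on what is new or still open speak of the compounds shown alone.

In a functional assay on NCI-H1299 cells (Homo sapiens) for inhibition, read by CCK-8 assay, with a stated time of 72 h, tested at 1 uM (a higher number here means more inhibition of growth at the concentration tested, a lower number less inhibition of growth), compound 1 (`CN(C)C(=O)c1cc2cnc(Nc3ccc(NC(=O)C4(C(=O)Nc5cccc(O)c5)CC4)cc3)nc2n1C1CCCC1`) gives 77.5%. This is the higher of the two numbers available. The other comes from compound 2 (`Nc1ccc(NC(=O)C2(C(=O)Nc3ccc(F)cc3)CC2)cc1F`), a smaller molecule lacking the shared core, which gives 46.2%, a gap beyond the scatter. Compound 3 (`CN(C)C(=O)c1cc2cnc(Nc3ccc(NC(=O)C4(C(=O)Nc5cccc(Br)c5)CC4)cc3)nc2n1C1CCCC1`) matches compound 1 except at one site, meta to a large group, with this difference: bromo in place of hydroxy on an aromatic carbon. Going by the values given here, no measured pair isolates this kind of change, so the data give no direct guide to its size. Starting from compound 1 at 77.5%, with the rest of the molecule unchanged, a small downward movement is expected, probably not beyond the scatter. The estimated step is a number 6.5 percentage points lower from compound 1 to compound 3 (within the scatter). For compound 3 the expected growth inhibition is 71%, with an estimated range of 52% to 88%.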

Compound 3, percent growth inhibition at one concentration: 46.6%
Compound 3: middle estimate off by 24.4 percentage points, on the high side; measured number outside the range, below it.
By their numbers in this assay, from the lowest: compounds 2 and 3 (each within the scatter of the next); then compound 1.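

In this assay, changing 3-hydroxyphenyl to 3-bromophenyl, with the rest of the molecule unchanged, gives a number 30.9 percentage points lower from compound 1 to compound 3 (beyond the scatter) at the single concentration tested. This is the only comparison among the compounds shown that isolates one site, and it shows that growth inhibition here depends strongly on which of these two groups sits on this aromatic carbon. The hydroxy carries a hydrogen-bond donor and acceptor where the bromo has neither, but no available measurement connects those counts or anything else to the size of the step.

With only two groups compared at this site, the compounds shown leave open whether the change reflects losing the hydroxy or gaining the bromo. A methoxy, an amine or a fluorine at the same place could help separate the two.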